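Swapping the amide aryl group for a thiophene

The source may report more compounds than this note shows. Statements on the series, on what has been measured and on what is new or still open speak of the compounds shown alone.

Measured compounds:
compound 1 `CCC(C)C(=O)Nc1c(C(O)(C(F)(F)F)C(F)(F)F)ccc2ccccc12` gives 177000 nM
compound 2 `O=C(Nc1c(C(O)(C(F)(F)F)C(F)(F)F)ccc2ccccc12)c1ccccc1` gives 44 nM
compound 3 `O=C(Nc1c(C(O)(C(F)(F)F)C(F)(F)F)ccc2ccccc12)c1ccc(Cl)c(Cl)c1` gives 194 nM

In an assay on LtK cells with ATP-sensitive inward rectifier potassium channel 11 (Homo sapiens) as the target (on this read-out higher numbers stand for an effect only at larger amounts of compound and lower numbers for an effect already at smaller amounts), compound 3 holds the second highest of the three numbers. Its nearest neighbour is compound 2, the step of a 4.4-fold higher number from compound 2 to compound 3 (0.64 log units; beyond the scatter) being a modest one; its furthest is compound 1, the step of a 910-fold lower number from compound 1 to compound 3 (2.96 log units; beyond the scatter) being large. Compound 4 `O=C(Nc1c(C(O)(C(F)(F)F)C(F)(F)F)ccc2ccccc12)c1cccs1` is not yet measured. It differs from compound 3 by thiophen-2-yl in place of 3,4-dichlorophenyl on a carbonyl carbon. Within the data shown here, the steps that bear on this change are those among the aromatic amides: the move a 4.4-fold higher number from compound 2 to compound 3 (0.64 log units; beyond the scatter) shows that the two chlorines raise the number modestly, while the steps of a 4000-fold lower number from compound 1 to compound 2 (3.60 log units; beyond the scatter) and a 910-fold lower number from compound 1 to compound 3 (2.96 log units; beyond the scatter) show that any aromatic group on the carbonyl carbon sits far below the sec-butyl amide. Thiophen-2-yl is an aromatic ring without chlorines, so it is expected to sit near compound 2, and compound 4 is estimated to give 70 nM in this assay, within 20 nM to 300 nM. This estimate means the step of a 2.8-fold lower number from compound 3 to compound 4 (0.44 log units; beyond the scatter) is expected, a modest move toward lower numbers.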

Compound 4, half-maximal effective concentration: 12 nM
Estimate against measurement, compound 4: 5.8-fold (0.77 log units) above, outside the stated range (below it).
By their numbers in this assay, from the lowest: compound 4; then compound 2; then compound 3; then compound 1.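

In this assay, among these compounds, the place on the carbonyl carbon separates aromatic rings more finely than the earlier compounds showed: thiophen-2-yl in place of phenyl gives a 3.7-fold lower number from compound 2 to compound 4 (0.56 log units; beyond the scatter), and in place of 3,4-dichlorophenyl it gives a 16-fold lower number from compound 3 to compound 4 (1.21 log units; beyond the scatter), so the five-membered ring with its sulfur does not simply match the unsubstituted phenyl amide. The distance from the sec-butyl amide also grows, with a 15000-fold lower number from compound 1 to compound 4 (4.17 log units; beyond the scatter), and compound 4 now has the lowest number of the four, its steps to all three others lying beyond the scatter. Nothing measured here speaks to the reason for this order.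

As far as these compounds go, it remains open whether a furan-2-yl or thiophen-3-yl ring at this place would follow thiophen-2-yl. From the compounds shown here alone, it is also open whether chlorine on the thiophene ring would raise the number, as the two chlorines do on the phenyl ring.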